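A few compounds are considered here, and "the series" means these few. Any claim that something is new, unique, unknown or untested is made for them only; others in the source may bear on it.

Measured in a functional assay on C8166 cells (Homo sapiens) for cytotoxicity, read by MTT assay; on this read-out lower numbers stand for higher toxicity in this test and higher numbers for lower toxicity in this test:
- Compound 1 `Cc1cccc(C(=O)Nc2cc(Cl)ccc2OCC(=O)Nc2ccc(S(N)(=O)=O)cc2C)c1`: 52900 nM
- Compound 2 `Cc1cc(S(N)(=O)=O)ccc1NC(=O)COc1ccc(Cl)cc1NC(=O)c1cc(Cl)ccc1Cl`: 42100 nM

Not yet measured: compound 3 `Cc1cc(S(N)(=O)=O)ccc1NC(=O)COc1ccc(Cl)cc1NC(=O)c1cccc2ccccc12`.

Among the measured compounds shown here, only two numbers exist so far. For the measured compounds named here, compound 2, at 42100 nM, stands within the scatter of compound 1, the only other measured compound.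

The next step keeps the core of compound 2 and has naphthalen-1-yl in place of 2,5-dichlorophenyl on a carbonyl carbon.

Going by the values given here, one measured step bears on this, made at the same place: a 1.3-fold lower number from compound 1 to compound 2 (0.10 log units; within the scatter). Exchanging one aryl group for another there left this assay without a change beyond the scatter. Among the compounds with values here, this is a single step, and no measured compound carries naphthalen-1-yl, so the evidence is thin and the range is kept wide. No step beyond the scatter is expected in this assay, and no direction is favoured.

The expected step is a 1.1-fold lower number from compound 2 to compound 3 (0.02 log units; within the scatter).

For compound 3 the estimated value is 40000 nM, with an expected range of 18000 nM to 85000 nM.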

Compound 3, half-maximal cytotoxic concentration: > 381000 nM
Compound 3 gave a limit, no number; the forecaster's own chance of this, stated with the estimate: 15%; middle value at least 9.5-fold (0.97 log units) from the limit.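

In this assay, the place on the carbonyl carbon is no longer silent: naphthalen-1-yl in place of 2,5-dichlorophenyl gives an at least 9.0-fold higher number from compound 2 to compound 3 (0.95 log units; beyond the scatter), and naphthalen-1-yl in place of 3-methylphenyl gives an at least 7.2-fold higher number from compound 1 to compound 3 (0.85 log units; beyond the scatter). Exchanging one aryl group for another here is therefore not always without consequence: the two groups with one aromatic ring, in compound 1 and compound 2, stand within the scatter of each other, while naphthalen-1-yl, with two aromatic rings, stands beyond the scatter from both. Compound 3 gives a limit and not a number, which leaves the full size of both steps unknown: the limit of > 381000 nM in this assay, at which 1 of the 3 values shown sits.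

Open, from the compounds shown here alone, is whether naphthalen-2-yl, a quinolinyl group with a ring nitrogen, or a saturated cyclohexyl group on the same carbonyl carbon would stand with compound 3 or with compound 1 and compound 2 in this assay. Only compound 3 carries two aromatic rings at this place, and a single compound cannot show whether the ring count or naphthalen-1-yl in particular goes with the step.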